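Methoxy to trifluoromethyl on the benzyl amide of compound 1

A few compounds are considered here, and "the series" means these few. Any claim that something is new, unique, unknown or untested is made for them only; others in the source may bear on it.

Working notes. Compound 1 `COc1cccc(CNC(=O)c2nc(Br)c3cccnc3c2N[C@H]2CC[C@H](N)CC2)c1` and compound 3 `N[C@H]1CC[C@H](Nc2c(C(=O)NCc3cccc(C(F)(F)F)c3)nc(Br)c3cccnc23)CC1` share one core with compound 2 `COC(=O)c1nc(Br)c2cccnc2c1N[C@H]1CC[C@H](N)CC1`. In a functional assay on MCF7 cells (Homo sapiens) for cytotoxicity, read by MTT assay, with a stated time of 72 h (on this read-out higher numbers stand for weaker inhibition and lower numbers for stronger inhibition), compound 1 gives "not determined" (no result reported), so no number stands for it. Compound 2 gives > 20000 nM, which is a limit of the assay and not a number, the sole measured point being (the limit of > 20000 nM in this assay, at which 1 of the 2 values shown sits). The change from compound 1 to compound 3 is trifluoromethyl in place of methoxy on an aromatic carbon. Within the data shown here, with no measured step to lean on, no shift beyond the scatter is expected in this assay. For compound 3 the expected value is 8000 nM, ranging from 1500 nM to 20000 nM.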

Compound 3, half-maximal inhibitory concentration: 15000 nM
For compound 3 the middle estimate is 1.9-fold (0.27 log units) below the measured one; measured number inside the range.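

No new step can be read: in this assay compound 1 gives "not determined" (no result reported), so compound 3 has no number to be set against. As far as these compounds go, how methoxy and trifluoromethyl on the benzyl amide compare in this assay stays open.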